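Bromo to Methyl on the Benzyl Ring: Expected Tolerance

The compounds below may be only part of what the source reports. "The series", "measured", "known", "first", "only" and "open" are said of these compounds alone.

Compound 3 `O=c1nc(N2CCN(NCc3ccc(Br)cc3)CC2)sc2c([N+](=O)[O-])cc(C(F)(F)F)cc12` was tested in an ADME assay on Vero cells (Chlorocebus sabaeus) for cytotoxicity, read by MTT assay, with a stated time of 72 h (a lower number here means that less compound is tolerated, a higher number that more compound is tolerated), and gave only a limit of the assay, > 64 ug/mL. The two compounds that differ from it in one place stand no differently. Compound 1 `CN(CC1CCCCC1)N1CCN(c2nc(=O)c3cc(C(F)(F)F)cc([N+](=O)[O-])c3s2)CC1` also gives a limit in this assay, > 64 ug/mL. Compound 2 `O=c1nc(N2CCN(NCc3ccc(OC(F)(F)F)cc3)CC2)sc2c([N+](=O)[O-])cc(C(F)(F)F)cc12` likewise gives a limit, > 64 ug/mL. The step that the two limits leave unreadable from compound 1 to compound 3 and the step that the two limits leave unreadable from compound 2 to compound 3 are therefore both unreadable, because the limit of > 64 ug/mL in this assay, at which 3 of the 3 values shown sit, holds all three values at the same point and leaves no number to compare.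

Compound 4 `Cc1ccc(CNN2CCN(c3nc(=O)c4cc(C(F)(F)F)cc([N+](=O)[O-])c4s3)CC2)cc1` differs from compound 3 by methyl in place of bromo on an aromatic carbon. For the measured compounds named here, the step that bears on this change is the one from compound 2 to compound 3, which exchanged one group at the same aromatic carbon of the benzyl ring and left the value at the limit; the step from compound 1 to compound 3, which rebuilt the whole substituent on the amine nitrogen of the ring, also left it there. With three such changes around compound 3 producing no readable movement in this assay, compound 4 is expected to show no step beyond the scatter, a step that the limit leaves unreadable from compound 3 to compound 4. Compound 4 is accordingly estimated at 80 ug/mL, with a range from 40 ug/mL to 200 ug/mL.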

Compound 4, half-maximal cytotoxic concentration: > 64 ug/mL
Compound 4: a limit, no number; the forecaster's own chance of this, stated with the estimate: 85%; the middle value lies beyond the limit too.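

In this assay compound 4 gives only a limit, > 64 ug/mL. For the compounds shown here, no step from compound 1, compound 2 or compound 3 to compound 4 can be read, because all four compounds stand at one point: the limit of > 64 ug/mL in this assay, at which 4 of the 4 values shown sit. The compounds shown leave open where the half-maximal cytotoxic concentration of any of them lies, and so whether methyl, bromo and trifluoromethoxy differ at all.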